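From 2-Fluorophenyl to 2-Methoxyphenyl in Compound 3

The source may hold more compounds than are shown below. What is called first, only, known or untested is meant among the compounds shown, and "the series" means these compounds.

Compound 2 `O=C(CN1CCN(c2ccccc2F)CC1)Nc1ccc(C(=O)/C=C/c2cn(Cc3ccc(Br)cc3)nn2)cc1` gives 9120 nM in a functional assay on HeLa cells (Homo sapiens) for inhibition, read by MTT assay (a lower number here means a stronger inhibitor, a higher number a weaker inhibitor), the lowest of the two numbers measured. Compound 1 `CCCCCCCCn1cc(/C=C/C(=O)c2ccc(NC(=O)CN3CCN(c4ccccc4F)CC3)cc2)nn1` gives 33800 nM in this assay, and the step of a 3.7-fold lower number from compound 1 to compound 2 (0.57 log units; beyond the scatter) concerned a different part of the shared core. Compound 3 `COc1ccccc1N1CCN(CC(=O)Nc2ccc(C(=O)/C=C/c3cn(Cc4ccc(Br)cc4)nn3)cc2)CC1` differs from compound 2 by methoxy in place of fluoro on an aromatic carbon. Among the compounds with values here, no measured step touches this position, and the expectation therefore rests on compound 2 at 9120 nM alone, with no step beyond the scatter expected. Compound 3 is estimated at 9000 nM, within 3500 nM to 25000 nM. The expected step is a 1.0-fold lower number from compound 2 to compound 3 (0.01 log units; within the scatter).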

Compound 3, half-maximal inhibitory concentration: 26400 nM
The estimate for compound 3 lay 2.9-fold (0.47 log units) below the measured number; the whole stated range lies below it.
By their numbers in this assay, from the lowest: compound 2; then compounds 3 and 1 (each within the scatter of the next).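

Methoxy in place of fluoro on an aromatic carbon gives a 2.9-fold higher number from compound 2 to compound 3 (0.46 log units; beyond the scatter) in this assay. This shows that the number responds to a change on this ring, at a carbon ortho to a large group, which the earlier step, made in a different part of the shared core, could not show. No evidence on the reason for this step is available.

The compounds shown leave open how a chloro group or an amine on this carbon would read. They also leave open whether methoxy in place of fluoro would give a similar step on compound 1.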